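Cytotoxicity notes: substituted benzyl groups on the shared core

The source may report more compounds than this note shows. Statements on the series, on what has been measured and on what is new or still open speak of the compounds shown alone.

Compound 2 `CN(C)CCCNc1nc2cc([N+](=O)[O-])ccc2nc1NCc1ccccc1` stands at the low end of the numbers shown in an ADME assay on HEK293 cells (Homo sapiens) for cytotoxicity, read by MTT assay, with a stated time of 24 h (on this read-out lower numbers stand for stronger inhibition and higher numbers for weaker inhibition), giving 2.74 ug/mL. Compound 3 `CN(C)CCCNc1nc2cc([N+](=O)[O-])ccc2nc1NCc1cccc(Br)c1` gives 3.66 ug/mL, which lies within the usual scatter of compound 2, while compound 1 `CN(C)CCCNc1nc2cc([N+](=O)[O-])ccc2nc1NCc1ccc(C(F)(F)F)cc1` gives 5.66 ug/mL, which lies beyond it. Compound 4 `CN(C)CCCNc1nc2cc([N+](=O)[O-])ccc2nc1NCc1ccc(Cl)c(C(F)(F)F)c1` differs from compound 2 in that (4-chloro-3-(trifluoromethyl)phenyl in place of phenyl on a saturated chain carbon bound to a nitrogen on an aromatic ring). Going by the values given here, two measured steps bear on this change, both involving compound 2: a 2.1-fold lower number from compound 1 to compound 2 (0.32 log units; beyond the scatter), and a 1.3-fold higher number from compound 2 to compound 3 (0.13 log units; within the scatter). Reversing the first, a trifluoromethyl on the aromatic carbon moved the number up beyond the scatter; a bromo on the aromatic carbon stayed within it. Compound 4 carries both a chlorine and a trifluoromethyl on its phenyl, so in this assay a modest rise is expected, about the size of the trifluoromethyl step. Compound 4 is estimated at 5.5 ug/mL, with a range from 2.7 ug/mL to 11 ug/mL. The expected step is a 2.0-fold higher number from compound 2 to compound 4 (0.30 log units; within the scatter).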

Compound 4, half-maximal inhibitory concentration: 3.26 ug/mL
Beside the measured number, compound 4's estimate is 1.7-fold (0.23 log units) above it; measured number inside the range.
By their numbers in this assay, from the lowest: compounds 2, 4, 3 and 1 (each within the scatter of the next, the first and the last beyond it).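

In this assay, 4-chloro-3-(trifluoromethyl)phenyl on a saturated chain carbon bound to a nitrogen on an aromatic ring stays close to both phenyl and 3-bromophenyl, with a 1.2-fold higher number from compound 2 to compound 4 (0.08 log units; within the scatter) and a 1.1-fold lower number from compound 3 to compound 4 (0.05 log units; within the scatter) both within the scatter. A trifluoromethyl on the phenyl therefore does not always go with a step beyond the scatter from compound 2: compound 1 shows such a step, while compound 4 does not. With a 1.7-fold lower number from compound 1 to compound 4 (0.24 log units; within the scatter) also within the scatter, compound 4 cannot be separated from any of the other three compounds, and only compound 1 and compound 2 remain apart.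

No measurement at hand gives a reason for these numbers. On these data alone, it stays open whether the same narrow spread holds when the phenyl carries an amine or a carboxylic acid.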